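A Chloro Group Added to the Bromo Compound

This account rests on a few compounds, and the source may have more. Where it says the series, first, only, none or still open, it means among the compounds named here.

In an ADME assay for permeability, using PAMPA, at pH 4 (on this read-out lower numbers stand for lower permeability and higher numbers for higher permeability), compound 2 (`Cc1[nH]c2ccccc2c(=O)c1Br`) gives 8.19 10^-6 cm/s, the lowest of three numbers. Compound 1 (`Cc1[nH]c2ccccc2c(=O)c1C1CCCCC1`) gives 260 10^-6 cm/s, and compound 3 (`Cc1[nH]c2ccccc2c(=O)c1/C=C/c1ccccc1`) gives 222 10^-6 cm/s, both well beyond the scatter from compound 2. Compound 4 (`Cc1[nH]c2ccc(Cl)cc2c(=O)c1Br`) is still unmeasured and differs from compound 2 by chloro in place of hydrogen on an aromatic carbon. For the measured compounds named here, only one measured step offers any guide, the large 32-fold lower number from compound 1 to compound 2 (1.50 log units; beyond the scatter), and it is an indirect one: there, bromo replaces cyclohexyl, and no measured step shows chloro replacing hydrogen. A much smaller upward move is expected, a 2.2-fold higher number from compound 2 to compound 4 (0.34 log units; beyond the scatter). For compound 4 the estimated value is 18 10^-6 cm/s, with an expected range of 6 10^-6 cm/s to 60 10^-6 cm/s.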

Compound 4, apparent permeability in the ADME assay: 84.5 10^-6 cm/s
Compound 4: middle estimate off by 4.7-fold (0.67 log units), on the low side; the whole stated range lies below it.
By their numbers in the ADME assay, from the lowest: compound 2; then compound 4; then compounds 3 and 1 (each within the scatter of the next).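

The earlier compounds shown here varied only the group that bromo occupies in compound 2. Here a second place on the shared core comes into play: in the ADME assay, chloro in place of hydrogen on an aromatic carbon goes with a 10-fold higher number from compound 2 to compound 4 (1.01 log units; beyond the scatter), while in a physicochemical assay for solubility, read by HPLC, at pH 7.4 (a higher number here means a more soluble compound, a lower number a less soluble compound), the same change goes with an at least 4.0-fold lower number from compound 2 to compound 4 (0.60 log units; beyond the scatter). In the physicochemical assay compound 4 gives 5000 nM. In the physicochemical assay compound 2 gives > 20000 nM, which is a limit of the assay: the limit of > 20000 nM in the physicochemical assay, at which 1 of the 2 values shown sits.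

As far as these compounds go, whether fluoro, methoxy or an amine at this place would give steps of like size stays open. So does whether chloro gives the same step with cyclohexyl in place of bromo.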